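A few compounds are considered here, and "the series" means these few. Any claim that something is new, unique, unknown or untested is made for them only; others in the source may bear on it.

Three compounds have been measured in a functional assay on A549 cells (Homo sapiens) for inhibition, read by MTT assay, with a stated time of 48 h; on this read-out higher numbers stand for weaker inhibition and lower numbers for stronger inhibition:

Compound 1, `C[Se]c1ccc(N(C)c2nc(C3CC3)nc3ccccc23)cc1`: 13 nM
Compound 2, `COc1ccc(N(C)c2nc(C)nc3ccccc23)cc1[Se]C`: 11 nM
Compound 3, `COc1ccc(N(C)c2nc(C)nc3ccccc23)cc1[Se]C#N`: 49 nM

Compound 1 and compound 2 differ in more than one place, and the difference between their two cores is not broken down here; their two numbers in this assay lie within the usual scatter of each other, so nothing can be said about which of them is stronger. Compound 2 and compound 3 share a core and differ in one place only: cyano in place of methyl on a selenium. This single change gives a 4.5-fold higher number from compound 2 to compound 3 (0.65 log units; beyond the scatter), a step that is beyond the scatter and counts as a modest weakening.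

Compound 4, `CN(c1ccc([Se]C#N)cc1)c1nc(C2CC2)nc2ccccc12`, has not yet been measured. It stands to compound 1 as compound 3 stands to compound 2: the difference is cyano in place of methyl on a selenium, and the surroundings of the selenium are the same in both pairs, so this is the same change made on a different core.

Going by the values given here, only one example of this change has been measured, so the expectation rests on a single pair. Because the change gave a 4.5-fold higher number from compound 2 to compound 3 (0.65 log units; beyond the scatter), a step of similar size is expected from compound 1, namely a 4.2-fold higher number from compound 1 to compound 4 (0.63 log units; beyond the scatter). On that basis compound 4 is estimated at 55 nM in this assay, with the range 25 nM to 130 nM allowing for the scatter of repeated measurements and for the fact that a change can act differently on a different core.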

Compound 4, half-maximal inhibitory concentration: 12 nM
Compound 4: the middle estimate sits 4.6-fold (0.66 log units) above what was measured; the measured number lies below the stated range.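

On the core of compound 1, placing cyano instead of methyl on the selenium gives a 1.1-fold lower number from compound 1 to compound 4 (0.03 log units; within the scatter) in this assay, so the numbers of this pair cannot be told apart. The change therefore does not carry over with the same size from one core to the other, and a step measured on one core proved a poor guide to the step on the other: the same change on two cores in this assay, a 4.5-fold higher number (0.65 log units; beyond the scatter) from compound 2 to compound 3 and a 1.1-fold lower number (0.03 log units; within the scatter) from compound 1 to compound 4, 4.8-fold (0.68 log units) apart, beyond the scatter of two such steps This shows that the effect of the change depends on the core in these two pairs, but it does not show why, since the two cores differ in more than one place and two pairs cannot give a rule for any further core.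

The compounds shown leave open which of the differences between the two cores separates the two outcomes, a question that cores differing in one place only could answer in this assay. They also leave open how other groups on the selenium would behave on each core, for example an ethyl group, a longer chain or a chain ending in an amine or a carboxylic acid.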